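Solubility expectation for a phenoxy analogue of compound 1

This account rests on a few compounds, and the source may have more. Where it says the series, first, only, none or still open, it means among the compounds named here.

Going by the values given here, compound 1 `O=C1N=C(Nc2ccccc2)S/C1=C/c1ccc(N2CCNCC2)cc1` gives 1.68 ug/mL in a physicochemical assay (Homo sapiens) for solubility, with a stated time of 18 h, at pH 7.4 (on this read-out higher numbers stand for higher solubility and lower numbers for lower solubility), the higher of the two numbers measured so far; compound 2 `O=C1N=C(Nc2ccccc2Cl)S/C1=C/c1ccc(N2CCNCC2)cc1` gives 0.14 ug/mL. Among the compounds with values here, the only measured step, a 12-fold lower number from compound 1 to compound 2 (1.08 log units; beyond the scatter), puts chloro in place of hydrogen on an aromatic carbon. Compound 3 `O=C1N=C(Nc2ccc(Oc3ccccc3)cc2)S/C1=C/c1ccc(N2CCNCC2)cc1` differs from compound 1 by phenoxy in place of hydrogen on an aromatic carbon. Within the data shown here, that one chloro step is the sole guide, large and downward, so a downward step beyond the scatter is expected here as well, an 8.4-fold lower number from compound 1 to compound 3 (0.92 log units; beyond the scatter). Compound 3 is therefore estimated at 0.2 ug/mL, with a range from 0.05 ug/mL to 0.8 ug/mL.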

Compound 3, solubility: 0.1 ug/mL
The estimate for compound 3 lay 2.0-fold (0.30 log units) above the measured number; measured number inside the range.
By their numbers in this assay, from the lowest: compounds 3 and 2 (each within the scatter of the next); then compound 1.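

Phenoxy, on an aromatic carbon para to a large group, gives a 17-fold lower number from compound 1 to compound 3 (1.23 log units; beyond the scatter) in this assay. With the chloro step, a 12-fold lower number from compound 1 to compound 2 (1.08 log units; beyond the scatter), both substitutions shown on this aromatic ring of the core of compound 1 are large and downward, and neither leaves the number of compound 1 in place. No measured property at hand bears on this result.

Still open, going by these compounds, is whether an amine or a carboxylic acid at the same place would lower the number too, or hold it near that of compound 1 at 1.68 ug/mL in this assay. A methoxy group at that place would show whether a small ether gives a step of similar size.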